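Oxetan-3-yl in Place of Ethyl on an Amine Nitrogen

The compounds below may be only part of what the source reports. "The series", "measured", "known", "first", "only" and "open" are said of these compounds alone.

In an in vitro ADME assay on microsomes from liver (Mus musculus) for pharmacokinetics, read by LC-MS, with a stated time of 10 min, tested at 1 uM (a higher number here means faster removal of the compound, a lower number slower removal), compound 1 (`Cc1cc(NC(=O)[C@H]2CN(C)C[C@@H]2c2ccc(/C=C/C(=O)Nc3ccccc3N)cc2)ccc1Cl`) gives 65 mL/min/kg while compound 2 (`CCN1C[C@H](C(=O)Nc2ccc(Cl)cc2)[C@@H](c2ccc(/C=C/C(=O)Nc3ccccc3N)cc2)C1`) gives 35 mL/min/kg and these two numbers lie within the usual scatter of each other. On the evidence so far, compound 2 therefore cannot be told apart from compound 1 in clearance.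

Compound 3 (`Nc1ccccc1NC(=O)/C=C/c1ccc([C@H]2CN(C3COC3)C[C@@H]2C(=O)Nc2ccc(Cl)cc2)cc1`) carries oxetan-3-yl in place of ethyl on an amine nitrogen in a ring and otherwise matches compound 2. Within the data shown here, the measured compounds offer no step that changes one place alone, so the data give no direct measure of this replacement and any expectation remains uncertain.

In this assay only a small step towards slower removal is expected, starting from compound 2 at 35 mL/min/kg and possibly staying within the scatter. The estimated change is a 1.4-fold lower number from compound 2 to compound 3 (0.15 log units; within the scatter) in that direction, though a result with no real difference would not be surprising. The clearance estimated for compound 3 is 25 mL/min/kg with an expected range from 12 mL/min/kg to 50 mL/min/kg in this measurement.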

Compound 3, clearance: 42 mL/min/kg
Compound 3: the middle estimate sits 1.7-fold (0.23 log units) below what was measured; the range from low to high includes it.
By their numbers in this assay, from the lowest: compounds 2, 3 and 1 (each within the scatter of the next).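

In this assay, the replacement of ethyl by oxetan-3-yl on the amine nitrogen in a ring gives a 1.2-fold higher number from compound 2 to compound 3 (0.08 log units; within the scatter), the first reading of a change in one place alone among these compounds. At this position, compound 3 therefore cannot be told apart from compound 2 in clearance, even though the entering group brings a four-membered non-aromatic ring and a hydrogen-bond acceptor that ethyl does not have. Nothing available bears on why the two compounds read alike.

Still open, as far as these compounds go, is whether other groups on this nitrogen, such as cyclopropyl, acetyl or a longer chain like 2-methoxyethyl, would give a step beyond the scatter, since a single replacement says little about the position as a whole. From the compounds shown here alone, it is also open whether oxetan-3-yl in place of ethyl would read the same way when the (4-chlorophenyl)carbamoyl group is exchanged for another amide, for example one carrying a pyridine ring.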